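The compounds below may be only part of what the source reports. "The series", "measured", "known", "first", "only" and "open" are said of these compounds alone.

Working notes on the series.

Three compounds are measured in an ADME assay on cells (Rhabdomyosarcoma cell, Homo sapiens) for cytotoxicity, read by MTT assay, with a stated time of 72 h; a higher number here means that more compound is tolerated, a lower number that less compound is tolerated. Compound 1, `Fc1ccccc1/C=N/c1sc2c(c1-c1nc3ccccc3s1)CCC2`, gives 270 ug/mL. Compound 2, `Clc1ccccc1/C=N/c1sc2c(c1-c1nc3ccccc3s1)CCC2`, gives 123 ug/mL. Compound 3, `Fc1ccccc1/C=N/c1sc2c(c1-c1nc3ccccc3s1)CCCC2`, gives 319 ug/mL. Compound 3 and compound 1 lie within the scatter of each other in this assay, so no order between them is claimed; compound 3 and compound 2 lie beyond the scatter of each other. The difference between the two cores, that of compound 1 and that of compound 3, is not broken down here.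

Among the measured compounds shown here, the one counted step in the set is chloro in place of fluoro on an aromatic carbon, which gives a 2.2-fold lower number from compound 1 to compound 2 (0.34 log units; beyond the scatter).

Compound 4, `Clc1ccccc1/C=N/c1sc2c(c1-c1nc3ccccc3s1)CCCC2`, is not yet measured in this assay. It stands to compound 3 as compound 2 stands to compound 1: chloro in place of fluoro on an aromatic carbon. The place of the change is described in the same words in both pairs, so this is taken as the same change on a different core.

With a single earlier example of the change, the expectation for compound 4 rests on that step alone: because a 2.2-fold lower number from compound 1 to compound 2 (0.34 log units; beyond the scatter) was seen on the core of compound 1, a step of similar size is expected on the core of compound 3, giving an estimated 2.2-fold lower number from compound 3 to compound 4 (0.34 log units; beyond the scatter). The estimate for compound 4 in this assay is 145 ug/mL, with a range from 80 ug/mL to 260 ug/mL to allow for the scatter and for the core being different.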

Compound 4, half-maximal cytotoxic concentration: 332 ug/mL
Compound 4: middle estimate off by 2.3-fold (0.36 log units), on the low side; the measured number lies above the stated range.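

On the core of compound 3, chloro in place of fluoro on an aromatic carbon, ortho to a large group, gives in this assay a 1.0-fold higher number from compound 3 to compound 4 (0.02 log units; within the scatter), so compound 3 and compound 4 cannot be put in an order. Set beside the earlier step, the gap between the two is no larger than two such steps can scatter: the same change on two cores in this assay, a 2.2-fold lower number (0.34 log units; beyond the scatter) from compound 1 to compound 2 and a 1.0-fold higher number (0.02 log units; within the scatter) from compound 3 to compound 4, 2.3-fold (0.36 log units) apart, within the scatter of two such steps. Among the compounds shown here, this shows that the series gives no firm ground for saying the change behaves differently on the two cores, but it does not show that the change carries over either, as the step beyond the scatter on the core of compound 1 is not matched by one beyond the scatter on the core of compound 3, and each core offers only a single pair.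

On these data alone, whether a group other than fluoro or chloro at this place, such as bromo, methoxy, an amine or a carboxylic acid, would give a step beyond the scatter in this assay on either core remains open. Also open, as far as these compounds go, is whether further pairs on these two cores would bring the steps closer together or set them further apart.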